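This account rests on a few compounds, and the source may have more. Where it says the series, first, only, none or still open, it means among the compounds named here.

Among the three compounds measured so far, compound 3 `O=C(Nc1ccc(C(=O)N2CCOCC2)cc1)c1cn(Cc2c(F)cccc2F)c2ccc(=O)[nH]c2c1=O` stands second highest in an in vitro assay on Sf21 cells for inhibition of high affinity 3',5'-cyclic-AMP phosphodiesterase 7A (Homo sapiens), read by scintillation proximity assay, with a stated time of 30 min (a higher number here means a weaker inhibitor, a lower number a stronger inhibitor), where compound 3 gives 188 nM. Compound 1 `CC(=O)Nc1ccc(NC(=O)c2cn(Cc3c(F)cccc3F)c3ccc(=O)[nH]c3c2=O)cc1` gives 24 nM in this assay, and compound 2 `N#Cc1cccc(NC(=O)c2cn(Cc3c(F)cccc3F)c3ccc(=O)[nH]c3c2=O)c1` gives 1070 nM, so the number for compound 3 lies between those two. Compound 4 `O=C(Nc1ccc(OC(F)F)cc1)c1cn(Cc2c(F)cccc2F)c2ccc(=O)[nH]c2c1=O` has not yet been measured. It differs from compound 3 in one place: difluoromethoxy in place of (morpholin-4-yl)carbonyl on an aromatic carbon. The group that leaves carries one six-membered non-aromatic ring with two hetero atoms; the group that enters has no ring; both sit on an aromatic carbon of a six-membered aromatic ring of carbon only, para to a large group. Among the measured compounds shown here, two measured steps bear on this change. The step of a 7.8-fold higher number from compound 1 to compound 3 (0.89 log units; beyond the scatter) exchanged one group at that same place for another and was modest. The step of a 45-fold higher number from compound 1 to compound 2 (1.65 log units; beyond the scatter) replaced the entire substituted phenyl group and was large. Since the change to compound 4 again exchanges only the group at that place, a modest step in this assay is expected, more likely toward a lower number than a higher one. The estimate for compound 4 is 120 nM, with a range from 30 nM to 500 nM, which means an expected step of a 1.6-fold lower number from compound 3 to compound 4 (0.19 log units; within the scatter).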

Compound 4, half-maximal inhibitory concentration: 71 nM
Estimate against measurement, compound 4: 1.7-fold (0.23 log units) above, within the range that was stated.
By their numbers in this assay, from the lowest: compound 1; then compound 4; then compound 3; then compound 2.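

In this assay, the place on an aromatic carbon para to a large group now has three groups that can be read against one another, and difluoromethoxy, with no ring and fewer heavy atoms, gives a lower number there than (morpholin-4-yl)carbonyl (a 2.6-fold lower number from compound 3 to compound 4 (0.42 log units; beyond the scatter)). Acetamido still holds the lowest number at this place (a 3.0-fold higher number from compound 1 to compound 4 (0.47 log units; beyond the scatter)), so neither the ring nor the larger group size tracks the order in a simple way across these three compounds, while the large step from the 3-cyanophenyl compound (a 15-fold lower number from compound 2 to compound 4 (1.18 log units; beyond the scatter)) exchanges the whole substituted phenyl group and cannot be assigned to a single change. Nothing measured here accounts for the order of these groups.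

On these data alone, how a methoxy group, with no fluorine, would stand against difluoromethoxy at this place remains open. As far as these compounds go, it is also open whether an amine, a carboxylic acid or a longer alkoxy chain on that aromatic carbon would come closer to acetamido or pass it.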